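Hydroxyquinoline amides: lipophilicity on the anilide ring

The source may hold more compounds than are shown below. What is called first, only, known or untested is meant among the compounds shown, and "the series" means these compounds.

Measured compounds:
compound 1 `O=C(Nc1ccccc1F)c1ccc2cccc(O)c2n1`, 2.5
compound 2 `O=C(Nc1ccc(Cl)cc1)c1ccc2cccc(O)c2n1`, 2.5

In a physicochemical assay for lipophilicity, read by HPLC (on this read-out lower numbers stand for lower lipophilicity and higher numbers for higher lipophilicity), compound 1 gives 2.5, and compound 2 gives 2.5; the two stand level on this assay. Within the data shown here, the one measured step, 4-chlorophenyl in place of 2-fluorophenyl on the amide-type nitrogen, gave no change at the digits printed from compound 1 to compound 2 (within the scatter).

Compound 3 `O=C(Nc1ccccc1C(F)(F)F)c1ccc2cccc(O)c2n1` is the next compound for this assay. It differs from compound 1 by trifluoromethyl in place of fluoro on an aromatic carbon; the new group sits ortho to a large group. Among the measured compounds shown here, no measured step parallels this exchange, so the step from compound 1 to compound 2 gives little guidance beyond showing that swapping halogen substituents on the anilide left this assay flat.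

Given the larger group entering, this assay is expected to rise by a number 0.60 log units higher from compound 1 to compound 3 (beyond the scatter) from compound 1. Compound 3 is estimated at 3.1, with a range from 2.7 to 3.5.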

Compound 3, partition coefficient: 2.5
The estimate for compound 3 lay 0.60 log units above the measured number; measured number below the stated range.
By their numbers in this assay, from the lowest: compounds 1, 2 and 3 (each within the scatter of the next).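

At this position, trifluoromethyl in place of fluoro gave no change at the digits printed from compound 1 to compound 3 (within the scatter) in this assay. The earlier step changed both the halogen and the place it occupied, whereas this one keeps the place and changes only the group, with 4 heavy atoms entering where 1 heavy atom leaves, and the read-out still stays flat. Nothing available bears on the reason for this flat result.

The substituents shown on this side of the amide are limited to fluoro, chloro and trifluoromethyl, so it remains open whether an amine, a carboxylic acid or a longer chain at this position would move this assay beyond the scatter. Also open, as far as these compounds go, is whether trifluoromethyl would read the same at the place that chloro holds in compound 2.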